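Bromo in Place of Methoxy: Expecting Compound 3

This account rests on a few compounds, and the source may have more. Where it says the series, first, only, none or still open, it means among the compounds named here.

Measured compounds:
compound 1, `COc1cccc(C(=O)n2c(-c3cn(C)c4ccccc34)nc3ccccc32)c1`: 10200 nM
compound 2, `COc1cccc(C(=O)n2c(-c3cn(C)c4ccc(Br)cc34)nc3ccccc32)c1`: 10800 nM

In a functional assay on A549 cells (Homo sapiens) for inhibition, read by MTT assay, with a stated time of 24 h (a higher number here means a weaker inhibitor of growth, a lower number a stronger inhibitor of growth), compound 2 gives 10800 nM, the highest of the two numbers, with compound 1 nearest to it; the step of a 1.1-fold higher number from compound 1 to compound 2 (0.02 log units; within the scatter) lies within the scatter, so the two compounds cannot be ordered. Compound 3 `Cn1cc(-c2nc3ccccc3n2C(=O)c2cccc(Br)c2)c2cc(Br)ccc21` differs from compound 2 by bromo in place of methoxy on an aromatic carbon, that is, a (3-methoxyphenyl)carbonyl becomes a (3-bromophenyl)carbonyl. Among the compounds with values here, no measured step shows this same exchange. Within the data shown here, the only step at hand, a 1.1-fold higher number from compound 1 to compound 2 (0.02 log units; within the scatter), concerns bromo in place of hydrogen on another ring and changed the number by an amount within the scatter. On this basis no step beyond the scatter is expected for compound 3, in either direction, as a 1.1-fold lower number from compound 2 to compound 3 (0.03 log units; within the scatter). Compound 3 is therefore estimated to give 10000 nM, with a range from 4000 nM to 25000 nM.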

Compound 3, concentration for 50% growth inhibition: 38500 nM
Compound 3: middle estimate off by 3.9-fold (0.59 log units), on the low side, and the stated range ends below it.
By their numbers in this assay, from the lowest: compounds 1 and 2 (each within the scatter of the next); then compound 3.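

In this assay the exchange of methoxy for bromo on the aromatic ring of the (3-methoxyphenyl)carbonyl gives a 3.6-fold higher number from compound 2 to compound 3 (0.55 log units; beyond the scatter) and so makes compound 3 a weaker inhibitor of growth, a modest step but the only one here beyond the scatter. The earlier compounds shown here showed only that bromo in place of hydrogen on the other ring gives a 1.1-fold higher number from compound 1 to compound 2 (0.02 log units; within the scatter) and leaves the two compounds unordered, whereas this position, meta to a large group, does respond to a change of substituent. No measurement at hand accounts for this shift.

Going by these compounds, whether the step follows from the arrival of bromo or the departure of methoxy stays open, and a hydrogen, a hydroxy group or an amine at this place would help to separate the two. Also open, on these data alone, is whether the same exchange gives a similar step on the core of compound 1, which has hydrogen in place of the bromo on the other ring.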